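Fluoro for Methyl Next to the Ring Nitrogen

The compounds below may be only part of what the source reports. "The series", "measured", "known", "first", "only" and "open" are said of these compounds alone.

Measured so far in a functional assay on HO8910 cells (Homo sapiens) for cytotoxicity, read by CCK-8 assay, with a stated time of 24 h; on this read-out lower numbers stand for stronger inhibition and higher numbers for weaker inhibition:
compound 1, `C/C(=C\c1cc(-c2ccccc2)co1)C(N)=O`, gives 42400 nM.
compound 2, `C/C(=C\c1cc(-c2cccnc2)co1)C(N)=O`, gives 8640 nM.
compound 3, `C/C(=C\c1cc(-c2ccc(C)nc2)co1)C(N)=O`, is reported only as a limit, > 50000 nM.

Compound 3 therefore stands at the weak end of the three, with no exact number known; it sits at the limit of > 50000 nM in this assay, at which 1 of the 3 values shown sits. Compound 4, `C/C(=C\c1cc(-c2ccc(F)nc2)co1)C(N)=O`, differs from compound 3 by fluoro in place of methyl on an aromatic carbon. Going by the values given here, only one measured step bears on this position: an at least 5.7-fold higher number from compound 2 to compound 3 (0.76 log units; beyond the scatter), which shows that putting methyl there made the number worse. Replacing that methyl with the smaller fluoro is expected to undo part of that loss in this assay, giving a lower number than the limit of compound 3, though a limit remains possible. Compound 4 is estimated at 25000 nM, in the range 6000 nM to 60000 nM, an expected step of an at least 2.0-fold lower number from compound 3 to compound 4 (0.30 log units; that floor lies within the scatter).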

Compound 4, half-maximal inhibitory concentration: 30000 nM
Compound 4: middle estimate off by 1.2-fold (0.08 log units), on the low side; the measured number falls inside the stated range.
By their numbers in this assay, from the lowest: compound 2; then compounds 4 and 1 (each within the scatter of the next). At a limit, above all of these: compound 3.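

In this assay, on these data alone, fluoro next to the ring nitrogen turns a limit into a readable number: the change is an at least 1.6-fold lower number from compound 3 to compound 4 (0.22 log units; that floor lies within the scatter) and its true size stays unknown. Compound 3 is only a limit: the limit of > 50000 nM in this assay, at which 1 of the 4 values shown sits. Fluoro still falls short of hydrogen at this place: the change is a 3.5-fold higher number from compound 2 to compound 4 (0.54 log units; beyond the scatter) and so both methyl and fluoro here leave the number higher than in compound 2.

As far as these compounds go, whether an amine or a methoxy group at this place would come closer to hydrogen stays open. So does whether any group here could give a lower number than compound 2.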